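From (3,4-dichlorophenyl)amino to 3,4-dichlorophenyl: working notes

The compounds below may be only part of what the source reports. "The series", "measured", "known", "first", "only" and "open" are said of these compounds alone.

Measured in an ADME assay on BJ cells (Homo sapiens) for cytotoxicity, with a stated time of 72 h; on this read-out lower numbers stand for an effect already at smaller amounts and higher numbers for an effect only at larger amounts of compound (both entries are limits of the assay, not numbers):
compound 1 `C=C[C@@](C)(/C=C/c1ccc(Nc2ccc(Cl)c(F)c2)cc1)CCC=C(C)C`: > 36600 nM
compound 2 `C=C[C@@](C)(/C=C/c1ccc(Nc2ccc(Cl)c(Cl)c2)cc1)CCC=C(C)C`: > 36600 nM

Compound 2 stands at a limit of the assay (> 36600 nM), so no number is available for it. Compound 3 `C=C[C@@](C)(/C=C/c1ccc(-c2ccc(Cl)c(Cl)c2)cc1)CCC=C(C)C` carries 3,4-dichlorophenyl in place of (3,4-dichlorophenyl)amino on an aromatic carbon, para to a large group (3,4-dichlorophenyl in place of (3,4-dichlorophenyl)amino on an aromatic carbon). Within the data shown here, the only measured step is a step that the two limits leave unreadable from compound 1 to compound 2, with chloro in place of fluoro, and it is a different change that gives no size to carry over. Because of the limit of > 36600 nM in this assay, at which 2 of the 2 values shown sit, compound 2 offers no number to start from, so no step beyond the scatter is expected in this assay and no direction can be given. The step expected is a step that the limit leaves unreadable from compound 2 to compound 3. Compound 3 is expected at about 40000 nM, with an estimated range from 15000 nM to 80000 nM.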

Compound 3, half-maximal effective concentration: > 36600 nM
Compound 3 ended at the assay's limit (the forecaster's own chance of this, stated with the estimate: 70%); the middle value lies beyond the limit too.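

In this assay no step can be read among compound 1, compound 2 and compound 3, since all three values are limits of the assay, not numbers: the limit of > 36600 nM in this assay, at which 3 of the 3 values shown sit.

On these data alone, whether 3,4-dichlorophenyl in place of (3,4-dichlorophenyl)amino changes the read-out at all stays open, as does how far each compound lies beyond its limit.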